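Working notes: cyclopropyl on the ring amide nitrogen

The compounds below may be only part of what the source reports. "The series", "measured", "known", "first", "only" and "open" are said of these compounds alone.

Measured so far in a functional assay on A549 cells (Homo sapiens) for antiproliferative activity, read by MTT assay, with a stated time of 72 h; a lower number here means a stronger inhibitor, a higher number a weaker inhibitor:
compound 1 `O=C1COc2ccc(-c3cnc(Cl)c(NS(=O)(=O)c4ccc(F)cc4)c3)cc2N1c1ccccc1` gives 14700 nM;
compound 2 `O=C1COc2ccc(-c3cnc(Cl)c(NS(=O)(=O)c4ccc(F)cc4)c3)cc2N1c1ccc(Cl)cc1` gives 21600 nM;
compound 3 `O=C1COc2ccc(-c3cnc(Cl)c(NS(=O)(=O)c4ccc(F)cc4)c3)cc2N1` gives > 40000 nM.

Compound 3 holds only a limit of the assay, not a number: the limit of > 40000 nM in this assay, at which 1 of the 3 values shown sits. Compound 3 therefore sits at the weak end of the three values shown.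

Compound 4 `O=C1COc2ccc(-c3cnc(Cl)c(NS(=O)(=O)c4ccc(F)cc4)c3)cc2N1C1CC1` differs from compound 3 by cyclopropyl in place of hydrogen on an amide-type nitrogen in a ring. Going by the values given here, the steps that bear on this change are those in which the substituent on that nitrogen is removed: an at least 2.7-fold higher number from compound 1 to compound 3 (0.43 log units; beyond the scatter) and an at least 1.8-fold higher number from compound 2 to compound 3 (0.26 log units; that floor lies within the scatter). Among the compounds with values here, both point to the unsubstituted nitrogen being the weaker arrangement, though the cyclopropyl group is not an aryl group and no measured step tests a small alkyl ring there. A modest improvement is therefore expected, with considerable uncertainty: the expected step is an at least 1.6-fold lower number from compound 3 to compound 4 (0.20 log units; that floor lies within the scatter). Compound 4 is estimated at 25000 nM, with a range from 9000 nM to 60000 nM.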

Compound 4, half-maximal inhibitory concentration: 4330 nM
Beside the measured number, compound 4's estimate is 5.8-fold (0.76 log units) above it, and the stated range ends above it.
By their numbers in this assay, from the lowest: compound 4; then compounds 1 and 2 (each within the scatter of the next). At a limit, above all of these: compound 3.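

On the amide-type nitrogen in a ring, an aryl group is not required: in this assay the change to cyclopropyl gives a 3.4-fold lower number from compound 1 to compound 4 (0.53 log units; beyond the scatter) and, with the 4-chlorophenyl group leaving, a 5.0-fold lower number from compound 2 to compound 4 (0.70 log units; beyond the scatter). Cyclopropyl also improves on hydrogen, with an at least 9.2-fold lower number from compound 3 to compound 4 (0.96 log units; beyond the scatter). That step is only a floor, as compound 3 holds a limit of the assay and not a number: the limit of > 40000 nM in this assay, at which 1 of the 4 values shown sits.

Open, as far as these compounds go, is whether this gain is specific to cyclopropyl or extends to methyl, ethyl, cyclobutyl or cyclohexyl on the same nitrogen. Also open, from the compounds shown here alone, is how a longer chain ending in an amine would fare there.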